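The compounds below may be only part of what the source reports. "The series", "measured", "known", "first", "only" and "open" are said of these compounds alone.

Compound 1 `CN(c1cccc2c1CN(c1nc(Nc3cc(C(F)(F)F)cc(C(F)(F)F)c3)ncc1C(F)(F)F)C2)S(C)(=O)=O` carries the shared core of the series. In a functional assay on OVCAR-3 cells (Homo sapiens) for antiproliferative activity, read by spectrophotometry, with a stated time of 2 days (on this read-out lower numbers stand for stronger inhibition of growth and higher numbers for weaker inhibition of growth), compound 1 gives only a limit, > 30000 nM. Compound 2 `CN(c1cccc2c1CN(c1nc(Nc3ccc(C(F)(F)F)cc3)ncc1C(F)(F)F)C2)S(C)(=O)=O` likewise gives a limit, > 30000 nM, in this assay. Compound 3 `CN(c1cccc2c1CN(c1nc(Nc3ccc(Cl)c(C(F)(F)F)c3)ncc1C(F)(F)F)C2)S(C)(=O)=O` also stands at a limit, > 50000 nM, in this assay. No number is known for compound 3, and the two other values shown are limits as well. For the measured compounds named here, the one measured step that touches the present change is a step that the two limits leave unreadable from compound 2 to compound 3, which the two limits leave unreadable. Compound 4 `Cc1ccc(Nc2ncc(C(F)(F)F)c(N3Cc4cccc(N(C)S(C)(=O)=O)c4C3)n2)c(Cl)c1` differs from compound 3 by 2-chloro-4-methylphenyl in place of 4-chloro-3-(trifluoromethyl)phenyl on a nitrogen on an aromatic ring. Going by the values given here, with every value so far sitting at the limit of > 30000 nM in this assay, at which 2 of the 3 values shown sit, or (the limit of > 50000 nM in this assay, at which 1 of the 3 values shown sits), no readable step gives a direction, so the step of an at least 1.2-fold lower number from compound 3 to compound 4 (0.09 log units; that floor lies within the scatter) is expected to stay within the scatter. For compound 4 the expected value is 40000 nM, between 10000 nM and 100000 nM, most likely reported again as a limit.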

Compound 4, concentration for 50% growth inhibition: > 30000 nM
Compound 4 ended at the assay's limit; the forecaster's own chance of this, stated with the estimate: 70%; the middle value is on the limit's open side.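

Compound 2, compound 3 and compound 4 each give only a limit in this assay, so the steps among them cannot be read. The compounds shown leave open whether any phenyl group on this nitrogen gives a measurable value.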